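A few compounds are considered here, and "the series" means these few. Any claim that something is new, unique, unknown or untested is made for them only; others in the source may bear on it.

Compounds measured so far in an assay on isolated protein for displacement of a labelled ligand from 5-hydroxytryptamine receptor 6 (Homo sapiens); on this read-out lower numbers stand for stronger inhibition and higher numbers for weaker inhibition:

Compound 1, `NC[C@@H]1CCCc2cc(S(=O)(=O)Cc3ccccc3)ccc21`: 158 nM
Compound 2, `CNC[C@@H]1CCCc2cc(S(=O)(=O)c3cc[nH]c3)ccc21`: 0.159 nM
Compound 3, `O=C(NC[C@@H]1CCCc2cc(S(=O)(=O)c3cccc(F)c3)ccc21)[C@H]1CCCN1`: 0.631 nM

Three compounds share the same core and differ in the group on the sulfonyl and in the substituent on the aminomethyl side. In this assay compound 1 gives 158 nM, the highest of the three numbers. Compound 2 gives 0.159 nM, the lowest. Compound 3, with 0.631 nM, stands second highest of the three: its number lies nearer to that of compound 2 than to that of compound 1, yet the gap to compound 2 is beyond the usual scatter, and the gap to compound 1 is far beyond it.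

Compound 4, `NC(=O)NC[C@@H]1CCCc2cc(S(=O)(=O)c3cccc(F)c3)ccc21`, has not yet been measured in this assay. It differs from compound 3 in one place: amino in place of pyrrolidin-2-yl on a carbonyl carbon. Going by the values given here, no step between two measured compounds follows this kind of change, so there is nothing to read the effect off from directly. The author nevertheless expects compound 4 to give a higher number than compound 3 in this assay, a step of a 16-fold higher number from compound 3 to compound 4 (1.20 log units; beyond the scatter) and thus beyond the scatter. The estimated value for compound 4 is 10 nM, with a range from 2 nM to 60 nM.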

Compound 4, inhibition constant: 0.2 nM
For compound 4 the middle estimate is 50-fold (1.70 log units) above the measured one; the whole stated range lies above it.
By their numbers in this assay, from the lowest: compounds 2 and 4 (each within the scatter of the next); then compound 3; then compound 1.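

In this assay the exchange of pyrrolidin-2-yl for amino on the carbonyl carbon, which turns ((pyrrolidin-2-yl)carbonyl)amino into ureido, brings a 3.2-fold lower number from compound 3 to compound 4 (0.50 log units; beyond the scatter) and so a modest gain in this read-out. Going by these compounds alone, this is the first pair in the set that differs in one place, and it shows that at this position the five-membered non-aromatic ring and its defined stereocentre can be given up, with the group on the sulfonyl held the same, and the number does not rise: a single amino on the carbonyl carbon serves at least as well as the larger pyrrolidin-2-yl. No measurement at hand accounts for the direction of this step.

The compounds shown leave open whether a methyl, a dimethylamino or a longer chain on the same carbonyl carbon would keep the number as low as amino does. Within the data shown here, they also leave open whether the same step would appear with another group on the sulfonyl, as this one pair is the only reading of the change.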